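Cyclohexyl for isobutyl in a series at the limit

The source may report more compounds than this note shows. Statements on the series, on what has been measured and on what is new or still open speak of the compounds shown alone.

Compound 1 `CCCn1nc(C(=O)N[C@H]2COc3ccccc3N(C)C2=S)nc1Cc1ccccc1` and compound 2 `CC(C)Cn1nc(C(=O)N[C@H]2COc3ccccc3N(C)C2=S)nc1Cc1ccccc1` share one core and differ only by methyl in place of hydrogen on a saturated chain carbon bound to two saturated chain carbons. In a toxicity assay on HT-29 cells (Homo sapiens) for cytotoxicity (a lower number here means that less compound is tolerated, a higher number that more compound is tolerated), compound 1 gives > 100000 nM, which is a limit of the assay rather than a number. In this assay compound 2 likewise gives > 100000 nM, again a limit. The step that the two limits leave unreadable from compound 1 to compound 2 is therefore unreadable in size, and the limit of > 100000 nM in this assay, at which 2 of the 2 values shown sit, is all that the two values show. Compound 3 `CN1C(=S)[C@@H](NC(=O)c2nc(Cc3ccccc3)n(C3CCCCC3)n2)COc2ccccc21` carries cyclohexyl in place of isobutyl on an aromatic nitrogen. Among the compounds with values here, the one measured step bears on this change only in that it, too, gives no readable size. Compound 3 is expected to stay at the limit as well, and the expected step that the limit leaves unreadable from compound 2 to compound 3 amounts to none beyond the scatter. Compound 3 is estimated at 150000 nM, between 50000 nM and 500000 nM.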

Compound 3, half-maximal cytotoxic concentration: > 100000 nM
Compound 3 gave a limit, no number; the forecaster's own chance of this, stated with the estimate: 80%; the middle value is on the limit's open side.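

Compound 3 also returns a limit in this assay, so its steps from compound 1 and compound 2 cannot be read: the limit of > 100000 nM in this assay, at which 3 of the 3 values shown sit.

The compounds shown leave open at what concentration any of the three becomes cytotoxic, and whether propyl, isobutyl and cyclohexyl on the aromatic nitrogen differ at all.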